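The source may hold more compounds than are shown below. What is called first, only, known or untested is meant among the compounds shown, and "the series" means these compounds.

Compound 1 `COc1ccc2c(=O)c(/C=C/C(=O)Nc3ccccc3)coc2c1` stands, in a functional assay on A549 cells (Homo sapiens) for inhibition, read by MTT assay, with a stated time of 48 h (on this read-out lower numbers stand for stronger inhibition and higher numbers for weaker inhibition), at 51000 nM, the higher of the two numbers measured outright. Compound 2 `Cc1ccc(CNC(=O)/C=C/c2coc3cc(O)ccc3c2=O)cc1` gives 17400 nM in this assay. Compound 3 `COc1ccc2c(=O)c(/C=C/C(=O)NCc3ccc(C)cc3)coc2c1` reaches only the limit of this assay, > 100000 nM. Compound 4 `COc1ccc2c(=O)c(/C=C/C(=O)Nc3cccc(C)c3)coc2c1` differs from compound 1 by methyl in place of hydrogen on an aromatic carbon. Within the data shown here, no measured step matches this change directly. The step of an at least 1.9-fold higher number from compound 1 to compound 3 (0.29 log units; that floor lies within the scatter) adds a methyl to the ring but also swaps phenyl for 4-methylbenzyl, so its floor reflects two changes at once. The step of an at least 5.7-fold higher number from compound 2 to compound 3 (0.75 log units; beyond the scatter) concerns the oxygen on the aromatic ring, a different place entirely. No shift beyond the scatter is therefore expected for compound 4 in this assay, estimated at 55000 nM, with a range from 20000 nM to 150000 nM. That expectation means a step of a 1.1-fold higher number from compound 1 to compound 4 (0.03 log units; within the scatter).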

Compound 4, half-maximal inhibitory concentration: > 100000 nM
Compound 4 gave a limit, no number (the forecaster's own chance of this, stated with the estimate: 30%); middle value at least 1.8-fold (0.25 log units) away from the limit.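

In this assay, compound 4 gives a limit, not a number. Taken alone, without the swap to 4-methylbenzyl that compound 3 also carries, the change from phenyl to 3-methylphenyl gives an at least 1.9-fold higher number from compound 1 to compound 4 (0.29 log units; that floor lies within the scatter), so no real loss can be claimed, though no gain in inhibition appears either. The step between compound 3 and compound 4 cannot be read, and the limit now recurs in this small set: the limit of > 100000 nM in this assay, at which 2 of the 4 values shown sit.

As far as these compounds go, how far this methyl truly weakens inhibition stays open. So does how an amine or a carboxylic acid at this place on the ring would read.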